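A few compounds are considered here, and "the series" means these few. Any claim that something is new, unique, unknown or untested is made for them only; others in the source may bear on it.

Compound 1 `COC(=O)N1N=C(c2ccc(OC)cc2)CC1c1cc(OC)c(OC)c(OC)c1`: 5000 nM
Compound 2 `CCOC(=O)N1N=C(c2ccc(OC)cc2)CC1c1cc(OC)c(OC)c(OC)c1`: 9270 nM
Compound 3 `CCOC(=O)N1N=C(c2cccc(O)c2)CC1c1cc(OC)c(OC)c(OC)c1`: 9750 nM

All three values come from a functional assay on A2780 cells (Homo sapiens) for antiproliferative activity, read by MTT assay, with a stated time of 48 h; a lower number here means a stronger inhibitor of growth, a higher number a weaker inhibitor of growth. Compound 4 `CCCOC(=O)N1N=C(c2cccc(O)c2)CC1c1cc(OC)c(OC)c(OC)c1` is not yet measured there. Compound 4 differs from compound 3 by methyl in place of hydrogen on a saturated chain carbon, two bonds along the chain from an oxygen next to a carbonyl group. The same kind of change has already been made once, from compound 1 to compound 2, (methyl in place of hydrogen on a saturated chain carbon bound to an oxygen next to a carbonyl group), where the step was a 1.9-fold higher number from compound 1 to compound 2 (0.27 log units; within the scatter). The two places are not identical: in compound 1 the carbon is bound to an oxygen next to a carbonyl group, while in compound 3 it lies two bonds along the chain from an oxygen next to a carbonyl group. The difference between the two cores, compound 1 against compound 3, is not broken down here; from compound 2 to compound 3 the step was a 1.1-fold higher number from compound 2 to compound 3 (0.02 log units; within the scatter). In this assay the step from compound 3 to compound 4 is expected to be a 1.3-fold higher number from compound 3 to compound 4 (0.12 log units; within the scatter), because the earlier step of a 1.9-fold higher number from compound 1 to compound 2 (0.27 log units; within the scatter) stayed small. Compound 4 is therefore estimated at 13000 nM, with a range from 6500 nM to 26000 nM.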

Compound 4, concentration for 50% growth inhibition: 11100 nM
Compound 4: the middle estimate sits 1.2-fold (0.07 log units) above what was measured; the measured number falls inside the stated range.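

In this assay, methyl in place of hydrogen on a saturated chain carbon, two bonds along the chain from an oxygen next to a carbonyl group, gives a 1.1-fold higher number from compound 3 to compound 4 (0.06 log units; within the scatter). Set beside the earlier methyl step on the core of compound 1, this step does not differ from it: the same change on two cores in this assay, a 1.9-fold higher number (0.27 log units; within the scatter) from compound 1 to compound 2 and a 1.1-fold higher number (0.06 log units; within the scatter) from compound 3 to compound 4, 1.6-fold (0.21 log units) apart, within the scatter of two such steps

Within these two pairs, the methyl step stays small on both cores, but the two methyls enter at different chain carbons, and two pairs show nothing about other cores or about a consistent direction of change.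

The compounds shown leave open whether a longer chain such as butoxy, or a chain ending in an amine, in place of propoxy would give a step beyond the scatter.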